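Adding Back a Dichlorophenyl Question: Compound 3

A few compounds are considered here, and "the series" means these few. Any claim that something is new, unique, unknown or untested is made for them only; others in the source may bear on it.

Compound 1 `NC1=NC2(CCOCC2)N(OCCCOc2ccc(F)cc2)C(N)=N1` gives 2380 nM
Compound 2 `NC1=NC2(CCOCC2)N(OCCCOc2ccc(Cl)cc2Cl)C(N)=N1` gives 330 nM

In a functional assay on HL-60 cells (Homo sapiens) for antiproliferative activity, read by MTT assay, with a stated time of 72 h (a higher number here means a weaker inhibitor, a lower number a stronger inhibitor), compound 2 has the lower of the two numbers (330 nM), which makes it the stronger inhibitor of this pair. The next compound, compound 3 (`NC1=NC2(CCOCC2)N(OCCCOc2cccc(Cl)c2)C(N)=N1`), has 3-chlorophenyl in place of 2,4-dichlorophenyl on an oxygen on a saturated carbon. Within the data shown here, only one measured step bears on this change, a swap of the group on that same oxygen. That step was a 7.2-fold lower number from compound 1 to compound 2 (0.86 log units; beyond the scatter) and it is modest. Two compounds cannot show what each chlorine contributes. Compound 3 loses the exact group found in the stronger compound, yet it still carries a chlorine, so a partial move back toward a weaker number is expected. The expected change is a 2.4-fold higher number from compound 2 to compound 3 (0.38 log units; beyond the scatter) in this assay and it remains uncertain. The estimate for compound 3 is 800 nM (expected range 300 nM to 2200 nM).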

Compound 3, half-maximal inhibitory concentration: 520 nM
Compound 3: the middle estimate sits 1.5-fold (0.19 log units) above what was measured; the measured number falls inside the stated range.
By their numbers in this assay, from the lowest: compounds 2 and 3 (each within the scatter of the next); then compound 1.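

In this assay, putting 3-chlorophenyl in place of 2,4-dichlorophenyl on the oxygen gives a 1.6-fold higher number from compound 2 to compound 3 (0.20 log units; within the scatter) and so, as far as this assay can tell, a ring with one chlorine serves this position as well as a ring with two. Among these compounds, the earlier pair could not show this, since its only step changed both the halogen and the number of halogens at once. Against 4-fluorophenyl, the single chlorine still gives a 4.6-fold lower number from compound 1 to compound 3 (0.66 log units; beyond the scatter) and so the second chlorine is not needed for a clear gap from compound 1.

Compound 1 and compound 3 differ in both the halogen and its place on the ring, so a 4-chlorophenyl or an unsubstituted phenyl group would be needed to separate those two changes. No measurement here explains why these groups give these numbers.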